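Fluoro Added to the Anilino Group of Compound 2

The compounds below may be only part of what the source reports. "The series", "measured", "known", "first", "only" and "open" are said of these compounds alone.

For the measured compounds named here, compound 1 `O=C(NC1CC1)c1ccc(-c2cnn3c(NCC4CCOCC4)nc(NC4CCCC4)nc23)cc1F` and compound 2 `Cc1cc(-c2cnn3c(NCC4CCOCC4)nc(Nc4ccccc4)nc23)ccc1C(=O)NC1CC1` share a core but differ in more than one place, so no single step between them is counted. In a functional assay on OVCAR-3 cells (Homo sapiens) for antiproliferative activity (a lower number here means a stronger inhibitor of growth, a higher number a weaker inhibitor of growth), compound 1 gives 1700 nM. In this assay compound 2 gives 1700 nM, level with compound 1 within the scatter. Compound 3 `Cc1cc(-c2cnn3c(NCC4CCOCC4)nc(Nc4cccc(F)c4)nc23)ccc1C(=O)NC1CC1` is not yet measured; it differs from compound 2 by fluoro in place of hydrogen on an aromatic carbon. Going by the values given here, no measured step of this kind exists here, so the expected step is a 1.1-fold lower number from compound 2 to compound 3 (0.05 log units; within the scatter), nothing beyond the scatter in either direction. For compound 3 the estimate is 1500 nM, with a range from 600 nM to 4000 nM.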

Compound 3, concentration for 50% growth inhibition: 58 nM
Beside the measured number, compound 3's estimate is 26-fold (1.41 log units) above it; the whole stated range lies above it.
By their numbers in this assay, from the lowest: compound 3; then compounds 1 and 2 (each within the scatter of the next).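

Going from anilino to (3-fluorophenyl)amino gives a 29-fold lower number from compound 2 to compound 3 (1.47 log units; beyond the scatter) in this assay. This shows that a single fluoro in place of hydrogen at this place on the aromatic ring can change the number far beyond the scatter, which compound 1 and compound 2, differing in more than one place, could not show. Nothing measured here speaks to what lies behind the step. Whether the effect is particular to fluoro stays open, since chloro, methoxy or an amine at this place has no value among the compounds shown. Also open, going by these compounds, is how fluoro would fare elsewhere on the same ring.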